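The compounds below may be only part of what the source reports. "The series", "measured", "known", "first", "only" and "open" are said of these compounds alone.

Among the compounds with values here, the three compounds measured so far share one core and differ only in the aryl group on the amide nitrogen. Compound 1 `O=C(CSc1nc(Nc2ccccc2)c2ccccc2n1)Nc1ccccc1Br` carries a 2-bromophenyl there, and in a functional assay on NCI-H1975 cells (Homo sapiens) for inhibition, read by MTT assay, with a stated time of 72 h (a lower number here means a stronger inhibitor, a higher number a weaker inhibitor), compound 1 gives 10300 nM. Compound 2 `O=C(CSc1nc(Nc2ccccc2)c2ccccc2n1)Nc1cccc(Cl)c1` carries a 3-chlorophenyl, and in this assay compound 2 gives 8460 nM. Compound 3 `O=C(CSc1nc(Nc2ccccc2)c2ccccc2n1)Nc1ccc(C(F)(F)F)cc1` carries a 4-(trifluoromethyl)phenyl, and in this assay compound 3 gives 11700 nM. The three values lie close together: the step of a 1.2-fold lower number from compound 1 to compound 2 (0.09 log units; within the scatter), the step of a 1.1-fold higher number from compound 1 to compound 3 (0.06 log units; within the scatter) and the step of a 1.4-fold higher number from compound 2 to compound 3 (0.14 log units; within the scatter) all stay within the scatter, so compound 1 cannot be told apart from either neighbour, its nearest being compound 3 and its furthest compound 2.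

Compound 4 `O=C(CSc1nc(Nc2ccccc2)c2ccccc2n1)Nc1ccc(F)c(Cl)c1` is the next member of the set. The change from compound 1 is 3-chloro-4-fluorophenyl in place of 2-bromophenyl on an amide-type nitrogen. The closest measured precedent is the move from 2-bromophenyl to 3-chlorophenyl, a 1.2-fold lower number from compound 1 to compound 2 (0.09 log units; within the scatter), which did nothing beyond the scatter, and the move to 4-(trifluoromethyl)phenyl, a 1.1-fold higher number from compound 1 to compound 3 (0.06 log units; within the scatter), was likewise flat. Nothing in these data suggests that a 3-chloro-4-fluorophenyl should behave otherwise, so the expected step is a 1.1-fold lower number from compound 1 to compound 4 (0.04 log units; within the scatter), no change beyond the scatter. Compound 4 is therefore estimated at 9500 nM in this assay, with a range from 4500 nM to 20000 nM.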

Compound 4, half-maximal inhibitory concentration: 9390 nM
Compound 4: middle estimate off by 1.0-fold (0.01 log units), on the high side; low and high end bracket the measured number.
By their numbers in this assay, from the lowest: compounds 2, 4, 1 and 3 (each within the scatter of the next).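

Placing fluoro in place of hydrogen on an aromatic carbon gives the first single-atom change in this series, and it leaves this assay flat, with a 1.1-fold higher number from compound 2 to compound 4 (0.05 log units; within the scatter) staying within the scatter. The 3-chloro-4-fluorophenyl group on the amide-type nitrogen also cannot be told apart from the 2-bromophenyl or the 4-(trifluoromethyl)phenyl group, as a 1.1-fold lower number from compound 1 to compound 4 (0.04 log units; within the scatter) and a 1.2-fold lower number from compound 3 to compound 4 (0.10 log units; within the scatter) both stay within the scatter as well. All four aryl groups at this position therefore now read alike in this assay, and no evidence at hand speaks to what lies behind this flat picture.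

As far as these compounds go, all four compounds carry a phenyl ring with fluorine, chlorine, bromine or trifluoromethyl on the amide-type nitrogen, so it remains open whether a carboxylic acid or an amine on that ring, or a longer alkyl chain in its place, would move the number beyond the scatter. The rest of the shared core, including the phenyl group on its other nitrogen, is the same throughout, so these compounds say nothing about how a change there would read in this assay as a measure of inhibition.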